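Trading an Amino Group for Hydrogen on the Shared Core

The source may report more compounds than this note shows. Statements on the series, on what has been measured and on what is new or still open speak of the compounds shown alone.

Of the compounds shown here, two have so far been measured in a functional assay on LOX IMVI cells (Homo sapiens) for cytotoxicity, read by sulforhodamine B assay, with a stated time of 48 h; a lower number here means a stronger inhibitor of growth, a higher number a weaker inhibitor of growth. Compound 1 `ClCc1cccc(Cn2cnc3c(Cl)nc(Cl)nc32)c1` gives 3380 nM. Within the data shown here, compound 2 `Nc1nc(Cl)c2ncn(Cc3ccccc3CCl)c2n1` gives 21900 nM, the highest of the two numbers; its only neighbour, compound 1, sits well below it, beyond the usual scatter.

Compound 3 `ClCc1ccccc1Cn1cnc2c(Cl)ncnc21` has not yet been measured. Against compound 2 its structure differs by hydrogen in place of amino on an aromatic carbon. Among the measured compounds shown here, no measured pair isolates this change, so its size is open. Compound 3 is nevertheless expected to give a lower number than compound 2, with the step of a 2.7-fold lower number from compound 2 to compound 3 (0.44 log units; beyond the scatter) expected to reach beyond the scatter. Compound 3 is estimated at 8000 nM, within 2500 nM to 25000 nM.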

Compound 3, concentration for total growth inhibition: 5240 nM
Beside the measured number, compound 3's estimate is 1.5-fold (0.18 log units) above it; measured number inside the range.
By their numbers in this assay, from the lowest: compounds 1 and 3 (each within the scatter of the next); then compound 2.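

Among these compounds, this pair is the first to isolate the aromatic carbon between two ring nitrogen atoms: in this assay, hydrogen in place of amino gives a 4.2-fold lower number from compound 2 to compound 3 (0.62 log units; beyond the scatter). The step is modest but beyond the scatter, so the amino group is not required for growth inhibition in this pair, and the number falls without it.

On these data alone, how a methyl group, a hydroxyl group or a longer amine would fare on this carbon remains open. No measurement here explains the step.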